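The compounds below may be only part of what the source reports. "The series", "measured", "known", "first", "only" and "open" are said of these compounds alone.

Measured compounds:
compound 1 `COC(=O)C1=C(C)NC(C)=C(C(=O)OC2C=CCCC2)C1c1cccc([N+](=O)[O-])c1` — 10 nM
compound 2 `COC(=O)C1=C(C)NC(C)=C(C(=O)OCc2ccc(F)c(F)c2)C1c1cccc([N+](=O)[O-])c1` — 20 nM
compound 3 `COC(=O)C1=C(C)NC(C)=C(C(=O)OC2Cc3ccccc3C2)C1c1cccc([N+](=O)[O-])c1` — 43 nM

All three share one core and differ only in the group on the oxygen next to the carbonyl group. In a functional assay on HEK293 cells for antagonist activity at Voltage-dependent L-type calcium channel subunit alpha-1D (Rattus norvegicus), read by FLIPR (on this read-out lower numbers stand for stronger inhibition and higher numbers for weaker inhibition), compound 2 stands second highest of the three numbers. Its nearest neighbour is compound 1, with a 2.0-fold higher number from compound 1 to compound 2 (0.30 log units; within the scatter); the furthest is compound 3, with a 2.2-fold higher number from compound 2 to compound 3 (0.33 log units; beyond the scatter). The whole spread of the series is set by a 4.3-fold higher number from compound 1 to compound 3 (0.63 log units; beyond the scatter).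

Compound 4 `COC(=O)C1=C(C)NC(C)=C(C(=O)OCc2ccc(-c3ccccc3)cc2)C1c1cccc([N+](=O)[O-])c1` is not yet measured. It differs from compound 2 as follows: 4-phenylphenyl in place of 3,4-difluorophenyl on a saturated chain carbon bound to an oxygen next to a carbonyl group

Every measured step bears on this change, since each swaps the group on that same oxygen, and none moved the number far: one within the scatter, two modest. The exchange of 3,4-difluorophenyl for 4-phenylphenyl is therefore expected to give, at most, a modest step in this assay, more likely toward a higher number than a lower one, as the step of a 1.5-fold higher number from compound 2 to compound 4 (0.18 log units; within the scatter) expresses. Compound 4 is estimated at 30 nM, with a range from 10 nM to 90 nM.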

Compound 4, half-maximal inhibitory concentration: 74 nM
For compound 4 the middle estimate is 2.5-fold (0.39 log units) below the measured one; the measured number falls inside the stated range.
By their numbers in this assay, from the lowest: compounds 1 and 2 (each within the scatter of the next); then compounds 3 and 4 (each within the scatter of the next).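

For the compounds shown here, replacing 3,4-difluorophenyl with 4-phenylphenyl on a saturated chain carbon bound to an oxygen next to a carbonyl group gives, in (this assay), a modest loss (a 3.7-fold higher number from compound 2 to compound 4 (0.57 log units; beyond the scatter)), so this position accepts a second six-membered aromatic ring, and 12 heavy atoms in place of 8, with the number still in the range of the earlier compounds. Compound 4 lies within the scatter of compound 3, so two different larger groups on this oxygen read alike here, although only these two compounds support that. No measurement at hand accounts for the step.

The change removes both fluorines and adds a ring at once, so an unsubstituted phenyl on that carbon would be needed to separate the two. Going by these compounds, whether an amine or a carboxylic acid on the terminal ring keeps the number in this range remains open.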